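Trifluoromethyl in Place of Chloro on Compound 1

The compounds below may be only part of what the source reports. "The series", "measured", "known", "first", "only" and "open" are said of these compounds alone.

In a functional assay on L1210 cells (Mus musculus) for cytotoxicity, read by MTT assay, with a stated time of 24 h (a lower number here means a stronger inhibitor, a higher number a weaker inhibitor), compound 1 `COc1cc(C(=O)/C=C/c2ccc(Cl)c(Cl)c2)cc(OC)c1OC` gives 44000 nM. Compound 2 `COc1cc(C(=O)/C=C/c2ccc(C)cc2)cc(OC)c1OC` gives 50500 nM, and compound 3 `COc1cc(C(=O)/C=C/c2c(Cl)cccc2Cl)cc(OC)c1OC` also gives 50500 nM. Compound 1 therefore stands within the scatter of both neighbours, and the numbers do not separate the three.

Compound 4 `COc1cc(C(=O)/C=C/c2ccc(Cl)c(C(F)(F)F)c2)cc(OC)c1OC` departs from compound 1 in one place: trifluoromethyl in place of chloro on an aromatic carbon. Trifluoromethyl replaces a chloro group on an aromatic carbon, ortho to the remaining chloro group and meta to a large group. Among the measured compounds shown here, no measured step makes this exact exchange. The closest evidence comes from changes to the same phenyl group. Replacing 3,4-dichlorophenyl with 4-methylphenyl gives a 1.1-fold higher number from compound 1 to compound 2 (0.06 log units; within the scatter), and replacing it with 2,6-dichlorophenyl gives a 1.1-fold higher number from compound 1 to compound 3 (0.06 log units; within the scatter). The remaining comparison gives no change at the digits printed from compound 2 to compound 3 (within the scatter). All three steps stay within the scatter, so no step beyond the scatter is expected in this assay, and no direction can be favoured. The expected step is a 1.0-fold higher number from compound 1 to compound 4 (0.02 log units; within the scatter). Compound 4 is estimated at 46000 nM, with an expected range from 25000 nM to 85000 nM.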

Compound 4, half-maximal inhibitory concentration: 47500 nM
Beside the measured number, compound 4's estimate is 1.0-fold (0.01 log units) below it; the range from low to high includes it.
By their numbers in this assay, from the lowest: compounds 1, 4, 2 and 3 (each within the scatter of the next).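

In this assay, trifluoromethyl in place of chloro on this aromatic carbon, ortho to a chloro group and meta to a large group, gives a 1.1-fold higher number from compound 1 to compound 4 (0.03 log units; within the scatter). The earlier steps shown here exchanged the whole substituted phenyl group, whereas this one changes a single group at this position and shows that four heavy atoms can enter where one left without a step beyond the scatter. Nothing at hand gives a reason for this result.

On these data alone, whether an amine or a carboxylic acid on the same aromatic carbon would move the number beyond the scatter stays open. As far as these compounds go, it also stays open whether trifluoromethyl in place of the remaining chloro group would leave the number within the scatter in the same way.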